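Replacing Diethylamino with Imidazolyl: What to Expect

The source may hold more compounds than are shown below. What is called first, only, known or untested is meant among the compounds shown, and "the series" means these compounds.

In a functional assay on SW-620 cells (Homo sapiens) for antiproliferative activity, read by MTT assay, with a stated time of 24 h (a lower number here means a stronger inhibitor, a higher number a weaker inhibitor), the measured compounds stand as follows.
Compound 1 `COc1ccc(C(=O)/C=C/c2ccc(F)cc2)c2c1C=CC(C)(C)O2`: the result for compound 1 is a limit of the assay, > 10000 nM.
Compound 2 `COc1ccc(C(=O)/C=C/c2ccc(N(C)C)cc2)c2c1C=CC(C)(C)O2`: compound 2 gives 570 nM.
Compound 3 `CCN(CC)c1ccc(/C=C/C(=O)c2ccc(OC)c3c2OC(C)(C)C=C3)cc1`: compound 3 gives 670 nM.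

Compound 3 and compound 2 lie within the scatter of each other, a 1.2-fold higher number from compound 2 to compound 3 (0.07 log units; within the scatter), and both stand far from compound 1. Compound 4 `COc1ccc(C(=O)/C=C/c2ccc(-n3ccnc3)cc2)c2c1C=CC(C)(C)O2` differs from compound 3 by 1H-imidazol-1-yl in place of diethylamino on an aromatic carbon. Going by the values given here, the steps that bear on this are the two that brought a dialkylamino group in place of fluoro, an at least 17-fold lower number from compound 1 to compound 2 (1.24 log units; beyond the scatter) and an at least 14-fold lower number from compound 1 to compound 3 (1.17 log units; beyond the scatter), both large. Compound 1 itself sits at the limit of > 10000 nM in this assay, at which 1 of the 3 values shown sits. The imidazol-1-yl group is neither a dialkylamino nor a fluoro, so a moderate upward step, a 4.5-fold higher number from compound 3 to compound 4 (0.65 log units; beyond the scatter), is expected. Compound 4 is therefore estimated at 3000 nM, with a range from 900 nM to 10000 nM.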

Compound 4, half-maximal inhibitory concentration: > 10000 nM
Compound 4: a limit, no number; the forecaster's own chance of this, stated with the estimate: 30%; middle value at least 3.3-fold (0.52 log units) away from the limit.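

In this assay, going by these compounds alone, the earlier compounds showed only that dialkylamino beats fluoro at this place; here a group of the same heavy-atom count as diethylamino, 1H-imidazol-1-yl, gives an at least 14-fold higher number from compound 3 to compound 4 (1.17 log units; beyond the scatter) and an at least 17-fold higher number from compound 2 to compound 4 (1.24 log units; beyond the scatter). So the activity does not follow from having a nitrogen on this aromatic carbon or from the size of the group alone. Compound 4 ends at a limit of the assay, as compound 1 does, so the step between them cannot be read: the limit of > 10000 nM in this assay, at which 2 of the 4 values shown sit.

As far as these compounds go, whether a ring amine such as pyrrolidine or morpholine, attached through its nitrogen, keeps the activity stays open. So does whether a plain amino group or dipropylamino does.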